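The source may hold more compounds than are shown below. What is called first, only, known or untested is meant among the compounds shown, and "the series" means these compounds.

Measured in a functional assay on MCF7 cells (Homo sapiens) for inhibition, read by colorimetric assay and MTT assay, with a stated time of 72 h; a lower number here means a stronger inhibitor, a higher number a weaker inhibitor:

- compound 1 `C=CCCCCOc1ccccc1-c1cnc(OCCC=C)n1C`: 8000 nM
- compound 2 `C=CCCCCOc1ccc(F)cc1-c1cnc(OCCC=C)n1C`: 43000 nM
- compound 3 `C=CCCCCOc1cc(F)ccc1-c1cnc(OCCC=C)n1C`: 59000 nM

Among these three, compound 1 stands lowest, and so is the strongest inhibitor in this assay at 8000 nM, with both of its steps to the others beyond the scatter.

The next compound, compound 4 `C=CCCCCOc1ccccc1-c1cnc(OCCCCC=C)n1C`, keeps the core of compound 1 and alters only one chain, which goes from (but-3-en-1-yl)oxy to (hex-5-en-1-yl)oxy. The change is but-3-en-1-yl in place of vinyl on a saturated chain carbon, two bonds along the chain from an oxygen on an aromatic ring.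

Within the data shown here, no measured step touches this chain. The only two available are a 5.4-fold higher number from compound 1 to compound 2 (0.73 log units; beyond the scatter) and a 7.4-fold higher number from compound 1 to compound 3 (0.87 log units; beyond the scatter), both fluoro in place of hydrogen on an aromatic carbon and both modest. They bear on the question only indirectly, by showing how far a small edit has moved the number on this core. They say nothing firm about direction for a longer chain. Among the measured compounds shown here, compound 1 does hold the lowest of the three numbers, which gives a slight lean upward, but no step clearly beyond the scatter is expected.

The expected change is a 1.5-fold higher number from compound 1 to compound 4 (0.18 log units; within the scatter).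

For compound 4 the estimated value is 12000 nM, with an expected range from 3500 nM to 40000 nM.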

Compound 4, half-maximal inhibitory concentration: 5000 nM
Beside the measured number, compound 4's estimate is 2.4-fold (0.38 log units) above it; measured number inside the range.
By their numbers in this assay, from the lowest: compounds 4 and 1 (each within the scatter of the next); then compounds 2 and 3 (each within the scatter of the next).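

In this assay the swap of (but-3-en-1-yl)oxy for (hex-5-en-1-yl)oxy gives a 1.6-fold lower number from compound 1 to compound 4 (0.20 log units; within the scatter) and so stays within the scatter, which means that but-3-en-1-yl in place of vinyl, on a saturated chain carbon, two bonds along the chain from an oxygen on an aromatic ring, does not separate compound 4 from compound 1. Among these compounds, the earlier compounds varied only aromatic carbons, where fluoro in place of hydrogen gave steps beyond the scatter, so this is the first reading on the chain itself, and here the edit leaves the two compounds indistinguishable in this assay. No supporting evidence accompanies this result that could account for it.

The compounds shown leave open how the number responds to a longer chain than hex-5-en-1-yl, to a saturated chain without the double bond, or to an amine or a carboxylic acid at the chain end. They also leave open whether fluoro on the aromatic carbons would give similar steps with the (hex-5-en-1-yl)oxy chain in place.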